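Trading a Bromophenyl Arm for a Fluorophenyl Arm

The compounds below may be only part of what the source reports. "The series", "measured", "known", "first", "only" and "open" are said of these compounds alone.

Measured compounds:
- compound 1, `C=CCn1c(=O)/c(=C\c2cccc(C)c2)[nH]c(=O)/c1=C\c1ccccc1OC`: 20400 nM
- compound 2, `C=CCn1c(=O)/c(=C\c2cccc(Br)c2)[nH]c(=O)/c1=C\c1ccccc1OC`: 5900 nM

Both compounds were tested in a functional assay on BGC-823 cells (Homo sapiens) for cytotoxicity, read by CCK-8 assay, with a stated time of 72 h; a higher number here means a weaker inhibitor, a lower number a stronger inhibitor. Among the measured compounds shown here, compound 2 gives the lowest of the two numbers, and the single measured step that separates it from compound 1 is a 3.5-fold lower number from compound 1 to compound 2 (0.54 log units; beyond the scatter). For the measured compounds named here, that step exchanged a methyl for a bromo on one of the two phenyl arms and is the only guide available.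

Compound 3, `C=CCn1c(=O)/c(=C\c2ccccc2F)[nH]c(=O)/c1=C\c1ccccc1OC`, differs from compound 2 by 2-fluorophenyl in place of 3-bromophenyl on a double-bonded chain carbon bound to an aromatic carbon. Going by the values given here, no measured step exchanges one halogen for another, nor replaces a whole substituted phenyl by a differently substituted one, so the measured step bears on this change only loosely: it shows that altering the substituent on this phenyl can move the number by a modest amount. Since a bromo rather than a methyl gave the lower number, losing the 3-bromophenyl is expected to cost some potency, with the number for compound 3 expected to drift back toward that of compound 1 by a 2.4-fold higher number from compound 2 to compound 3 (0.38 log units; beyond the scatter). The value expected for compound 3 is 14000 nM, within a range from 5000 nM to 40000 nM.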

Compound 3, half-maximal inhibitory concentration: 18900 nM
Compound 3: the middle estimate sits 1.4-fold (0.13 log units) below what was measured; low and high end bracket the measured number.
By their numbers in this assay, from the lowest: compound 2; then compounds 3 and 1 (each within the scatter of the next).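

In this assay, the change to 2-fluorophenyl brings a 3.2-fold higher number from compound 2 to compound 3 (0.51 log units; beyond the scatter), so the lower number of compound 2 does not carry over to every halogen-bearing phenyl on this carbon: a halogen on this arm is not enough by itself to keep it. The other new comparison gives a 1.1-fold lower number from compound 1 to compound 3 (0.03 log units; within the scatter), which lies within the scatter, so the 2-fluorophenyl and 3-methylphenyl arms cannot be told apart here, and of the three arms only the 3-bromophenyl of compound 2 stands apart from the others. Nothing available here offers an explanation for these differences.

This single change swaps the halogen and also moves it on the phenyl, so the three compounds cannot show which of those two differences matters; 3-fluorophenyl or 2-bromophenyl at this spot would pull them apart. From the compounds shown here alone, it also remains open how this arm would behave with a phenyl carrying an amine or a carboxylic acid, and whether the 3-bromophenyl arm keeps its lower number when the rest of the shared core is altered.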